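Acetamido to Amino: Expected Cytotoxicity of Compound 4

The source may report more compounds than this note shows. Statements on the series, on what has been measured and on what is new or still open speak of the compounds shown alone.

Measured so far in an ADME assay on MT4 cells (Homo sapiens) for cytotoxicity, read by MTT assay, with a stated time of 4 days; on this read-out higher numbers stand for lower toxicity in this test and lower numbers for higher toxicity in this test:
compound 1, `COc1ccccc1-c1cc(=O)c2cc(NC(C)=O)ccc2o1`, gives 226000 nM
compound 2, `COc1ccccc1-c1cc(=O)c2cc(N)ccc2o1`, gives 198000 nM
compound 3, `CC(=O)Nc1ccc2oc(-c3ccccc3)c(O)c(=O)c2c1`, gives 64700 nM

Compound 1 and compound 2 share one core and differ only by hydrogen in place of acetyl on a nitrogen on an aromatic ring; that change produced a 1.1-fold lower number from compound 1 to compound 2 (0.06 log units; within the scatter). Compound 3 has a different core, and the difference between the two cores is not broken down here. Compound 4, `Nc1ccc2oc(-c3ccccc3)c(O)c(=O)c2c1`, has not yet been measured in this assay. It differs from compound 3 by hydrogen in place of acetyl on a nitrogen on an aromatic ring, the same change that separates compound 1 from compound 2. Because the matching step a 1.1-fold lower number from compound 1 to compound 2 (0.06 log units; within the scatter) lay within the scatter, little movement is expected. The expected step for compound 4 is a 1.1-fold lower number from compound 3 to compound 4 (0.03 log units; within the scatter). The estimate for compound 4 in this assay is 60000 nM, expected to fall between 30000 nM and 120000 nM.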

Compound 4, half-maximal cytotoxic concentration: 217000 nM
For compound 4 the middle estimate is 3.6-fold (0.56 log units) below the measured one; measured number outside the range, above it.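

In this assay, putting hydrogen in place of acetyl on the nitrogen gave a 3.4-fold higher number from compound 3 to compound 4 (0.53 log units; beyond the scatter), which on this read-out means lower toxicity in this test. Two pairs cannot show which part of the cores is responsible, nor that the difference would hold in other cores. What they do show is that the size of this step did not carry over unchanged from one core to the other: the same change on two cores in this assay, a 1.1-fold lower number (0.06 log units; within the scatter) from compound 1 to compound 2 and a 3.4-fold higher number (0.53 log units; beyond the scatter) from compound 3 to compound 4, 3.8-fold (0.58 log units) apart, beyond the scatter of two such steps

The compounds shown leave open how each core would respond to another group on that nitrogen, such as methanesulfonyl or a longer acyl chain. They also leave open whether a third core would behave like the first pair or the second.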